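A few compounds are considered here, and "the series" means these few. Any claim that something is new, unique, unknown or untested is made for them only; others in the source may bear on it.

Working notes on the series

All four compounds share one core; the variable part is the methylphenyl carried on an aromatic nitrogen of the five-membered aromatic ring with 3 nitrogen. Compound 1 `Cc1cccc(-n2cc(-c3cccc(NS(=O)(=O)c4c[nH]c(=O)[nH]c4=O)c3)nn2)c1` and compound 2 `Cc1ccc(-n2cc(-c3cccc(NS(=O)(=O)c4c[nH]c(=O)[nH]c4=O)c3)nn2)cc1` form one pair. In an ADME assay on GES1 cells (Homo sapiens) for cytotoxicity, read by MTT assay, with a stated time of 24 h (a higher number here means that more compound is tolerated, a lower number that less compound is tolerated), compound 1 gives 18500 nM, and compound 2 gives 15800 nM. The change between them, (4-methylphenyl in place of 3-methylphenyl on an aromatic nitrogen), produced a 1.2-fold lower number from compound 1 to compound 2 (0.07 log units; within the scatter), so within this pair the two values are not distinguishable.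

Compound 3 `Cc1cccc(-n2cc(-c3ccc(NS(=O)(=O)c4c[nH]c(=O)[nH]c4=O)cc3)nn2)c1` carries the same 3-methylphenyl as compound 1 on a core that differs from the core of compound 1; how the two cores differ is not broken down here. In this assay compound 3 gives 28300 nM, close to the values of compound 1 and compound 2.

Compound 4 `Cc1ccc(-n2cc(-c3ccc(NS(=O)(=O)c4c[nH]c(=O)[nH]c4=O)cc3)nn2)cc1` is not yet measured. It relates to compound 3 as compound 2 relates to compound 1: the change 4-methylphenyl in place of 3-methylphenyl on an aromatic nitrogen is the same change as 4-methylphenyl in place of 3-methylphenyl on an aromatic nitrogen, made at the same place. Because a 1.2-fold lower number from compound 1 to compound 2 (0.07 log units; within the scatter) was within the usual scatter, the step expected from compound 3 to compound 4 in this assay is also small, estimated as a 1.1-fold lower number from compound 3 to compound 4 (0.05 log units; within the scatter). The value for compound 4 in this assay is therefore estimated at 25000 nM, with an expected range from 12000 nM to 50000 nM. This rests on one measured pair only.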

Compound 4, half-maximal cytotoxic concentration: "not toxic" (no number reported)
The entry for compound 4 holds no number, and the estimate cannot be compared.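

In this assay, among the compounds shown here, compound 4 is recorded only as "not toxic", with no number, so no step from compound 3 to compound 4 can be read. The compounds shown leave open whether 4-methylphenyl in place of 3-methylphenyl has any measurable effect on the core of compound 3. No data shown here offer an explanation for this result.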